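The compounds below may be only part of what the source reports. "The series", "measured", "known", "first", "only" and "open" are said of these compounds alone.

Three compounds share one core and differ only in the aryl group on the double-bonded chain. Compound 1 `Cc1c(C(=O)/C=C/c2ccc(Cl)cc2)[n+]([O-])c2ccccc2[n+]1[O-]` carries a chlorophenyl, and in a functional assay on HSC-2 cells (Homo sapiens) for cytotoxicity, with a stated time of 48 h (a higher number here means that more compound is tolerated, a lower number that less compound is tolerated), compound 1 gives 13000 nM. Compound 2 `Cc1c(C(=O)/C=C/c2ccc(Cl)c(Cl)c2)[n+]([O-])c2ccccc2[n+]1[O-]` carries a second chloro, and in this assay compound 2 gives 17000 nM. Compound 3 `Cc1ccc(/C=C/C(=O)c2c(C)[n+]([O-])c3ccccc3[n+]2[O-])cc1` carries a methylphenyl, and in this assay compound 3 gives 8400 nM, the lowest of the three numbers; its gap to compound 1, a 1.5-fold lower number from compound 1 to compound 3 (0.19 log units; within the scatter), stays within the scatter, while a 2.0-fold lower number from compound 2 to compound 3 (0.31 log units; beyond the scatter) is a modest step.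

Compound 4 `Cc1c(C(=O)/C=C/c2ccc(Br)cc2)[n+]([O-])c2ccccc2[n+]1[O-]` differs from compound 3 by bromo in place of methyl on an aromatic carbon. The closest measured step is the exchange of one halogen for methyl, a 1.5-fold lower number from compound 1 to compound 3 (0.19 log units; within the scatter), which stayed within the scatter, and adding a further chloro, a 1.3-fold higher number from compound 1 to compound 2 (0.12 log units; within the scatter), also stayed within it. Bromo is expected to behave much like the chloro of compound 1, which gives 13000 nM. Compound 4 is therefore expected to give about 12000 nM in this assay, between 5000 nM and 30000 nM. That would mean a 1.4-fold higher number from compound 3 to compound 4 (0.15 log units; within the scatter), a step not expected to exceed the scatter.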

Compound 4, half-maximal cytotoxic concentration: 19000 nM
Beside the measured number, compound 4's estimate is 1.6-fold (0.20 log units) below it; low and high end bracket the measured number.
By their numbers in this assay, from the lowest: compounds 3, 1, 2 and 4 (each within the scatter of the next, the first and the last beyond it).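

In this assay, among these compounds, bromo in place of methyl on the aromatic carbon para to a large group gives a 2.3-fold higher number from compound 3 to compound 4 (0.35 log units; beyond the scatter), the first single-atom exchange at this carbon to pass the scatter. Among the halogen-bearing compounds the numbers stay close, with a 1.5-fold higher number from compound 1 to compound 4 (0.16 log units; within the scatter) and a 1.1-fold higher number from compound 2 to compound 4 (0.05 log units; within the scatter) both within the scatter, so 4-bromophenyl cannot be told apart from the chlorinated aryl groups; compound 1 keeps this from being a clean split between halogen and methyl, as it lies within the scatter of compound 3 as well as of compound 4. Nothing measured here explains the gap between methyl and bromo.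

Going by these compounds, all four aryl groups carry only halogen or methyl, so the range of this position remains open. An amine, a carboxylic acid or a methoxy group at the same carbon could move the number much further or hardly at all.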